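The source may hold more compounds than are shown below. What is called first, only, known or untested is meant among the compounds shown, and "the series" means these compounds.

The series shares one core, shown with compound 1 `CCC(CC)/N=c1\c(O)c(O)\c1=N/Cc1ccc(C#N)cc1`. Among the compounds with values here, in a functional assay for inhibition, with Rattus norvegicus as the target (on this read-out lower numbers stand for stronger inhibition and higher numbers for weaker inhibition), compound 1 gives 1300 nM, the lowest of the two numbers measured so far. Within the data shown here, compound 2 `COc1ccc(C/N=c2\c(O)c(O)\c2=N/C(C)(C)C)cc1` differs from compound 1 in more than one place, so no single step joins the two; in this assay compound 2 gives 4800 nM, a weaker result that lies beyond the scatter when set beside compound 1.

Compound 3 `CC(C)(CO)/N=c1\c(O)c(O)\c1=N/Cc1ccc(C#N)cc1` has not been measured. It differs from compound 1 at one place: 1-(hydroxymethyl)-1-methylethyl in place of pentan-3-yl on a double-bonded nitrogen. Among the measured compounds shown here, no measured pair differs at only this place, so the direction of this step has no precedent, and the hydroxymethyl group has no counterpart among the measured compounds.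

The step from compound 1 to compound 3 is expected to be small, a 1.5-fold higher number from compound 1 to compound 3 (0.19 log units; within the scatter), with a slight loss of potency held somewhat more likely than a gain. For compound 3 in this assay the estimate is 2000 nM, with a range from 700 nM to 6000 nM.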

Compound 3, half-maximal inhibitory concentration: 21300 nM
Compound 3: the middle estimate sits 11-fold (1.03 log units) below what was measured; measured number outside the range, above it.
By their numbers in this assay, from the lowest: compound 1; then compound 2; then compound 3.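

Within the data shown here, this position, on a double-bonded nitrogen, is sensitive to the group it carries: in this assay, 1-(hydroxymethyl)-1-methylethyl in place of pentan-3-yl gives a 16-fold higher number from compound 1 to compound 3 (1.21 log units; beyond the scatter) and is the first single-place step. Both groups have 5 heavy atoms and no ring, so the large loss of inhibition comes without any change in heavy-atom count. What differs by count is that one carbon gives way to an oxygen, and a hydrogen-bond donor and acceptor enter where pentan-3-yl has neither; nothing at hand shows which feature of this exchange accounts for the loss.

Still open, as far as these compounds go, is whether the loss follows the oxygen or the branched carbon frame, a question that 1,1-dimethylpropyl, the all-carbon counterpart of the new group, or an aminomethyl-bearing analogue at this position on the core of compound 1 could help settle. Also open is whether the step keeps its size when the group on the other nitrogen changes, since this exchange is shown only once.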